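The source may report more compounds than this note shows. Statements on the series, on what has been measured and on what is new or still open speak of the compounds shown alone.

Compound 2 `O=C(c1ccc(OCCCN2CC[C@H](NS(=O)(=O)c3ccc(F)cc3)C2)cc1)C1CC1` sits at the strong end of the three numbers measured in an assay on isolated protein for binding affinity to histamine H2 receptor (Homo sapiens) (a lower number here means a stronger inhibitor, a higher number a weaker inhibitor), where compound 2 gives 500 nM. Compound 1 `CC(=O)c1ccc(OCCCN2CC[C@H](NS(=O)(=O)c3ccc(C#N)cc3)C2)cc1` gives 2300 nM in this assay, a weaker result that lies beyond the scatter from compound 2, and compound 3 `O=C(N[C@H]1CCN(CCCOc2ccc(C(=O)C3CC3)cc2)C1)c1csc(-c2cccnc2)n1` gives 4000 nM, further still. Compound 4 `O=C(c1ccc(OCCCN2CC[C@H](NS(=O)(=O)c3cccc(Cl)c3)C2)cc1)C1CC1` has not been measured; it differs from compound 2 in one place: 3-chlorophenyl in place of 4-fluorophenyl on a sulfonyl sulfur. Among the compounds with values here, no measured pair shows the effect of this exchange, so the size of the step is uncertain. The step from compound 2 to compound 4 is expected to be small, possibly within the scatter, at a 1.2-fold higher number from compound 2 to compound 4 (0.08 log units; within the scatter). Compound 4 is therefore estimated at 600 nM, with a range from 150 nM to 2500 nM.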

Compound 4, inhibition constant: 700 nM
Compound 4: the middle estimate sits 1.2-fold (0.07 log units) below what was measured, and the stated range covers the measured number.
By their numbers in this assay, from the lowest: compounds 2 and 4 (each within the scatter of the next); then compounds 1 and 3 (each within the scatter of the next).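

In this assay, replacing 4-fluorophenyl with 3-chlorophenyl on a sulfonyl sulfur gives a 1.4-fold higher number from compound 2 to compound 4 (0.15 log units; within the scatter), so this step stays within the scatter. Because the atom on the ring and the number in the group's name both differ, this single step cannot separate the two changes. Nothing available here bears on why the step is this size. The compounds shown leave open how a pyridyl ring, a 3-aminophenyl or a methyl group on the same sulfonyl sulfur would read in this assay.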